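This account rests on a few compounds, and the source may have more. Where it says the series, first, only, none or still open, it means among the compounds named here.

Measured so far:
compound 1 `CC(C)=CCc1cc(C(=O)Nc2cc3ccc(Oc4ccc(C(C)(C)C)cc4)c(C)c3oc2=O)ccc1O`: 68300 nM
compound 2 `COc1cccc(-c2cc(C(=O)Nc3cc4ccc(Oc5ccc(C(C)(C)C)cc5)c(C)c4oc3=O)ccc2OC)c1`: > 100000 nM
compound 3 `COc1ccc(Nc2ccc3cc(NC(=O)c4ccc(O)c(CC=C(C)C)c4)c(=O)oc3c2C)cc1`: > 100000 nM

In a functional assay on SK-BR-3 cells (Homo sapiens) for antiproliferative activity (a lower number here means a stronger inhibitor, a higher number a weaker inhibitor), compound 1 gives 68300 nM. For compound 2 the value > 100000 nM in this assay is a limit, not a number. For compound 3 the value > 100000 nM in this assay is likewise a limit. The change (4-methoxyphenyl)amino in place of 4-(tert-butyl)phenoxy on an aromatic carbon gave an at least 1.4-fold higher number from compound 1 to compound 3 (0.16 log units; that floor lies within the scatter), a floor set by the limit of > 100000 nM in this assay, at which 2 of the 3 values shown sit. The difference between the cores of compound 1 and compound 2 is not broken down here. Compound 4 `COc1ccc(Nc2ccc3cc(NC(=O)c4ccc(OC)c(-c5cccc(OC)c5)c4)c(=O)oc3c2C)cc1` has not yet been measured in this assay; it arises from compound 2 by the same change, ((4-methoxyphenyl)amino in place of 4-(tert-butyl)phenoxy on an aromatic carbon). Because compound 2 already sits at the limit of > 100000 nM in this assay, at which 2 of the 3 values shown sit, compound 4 is expected to give 150000 nM in this assay, an estimated step that the limit leaves unreadable from compound 2 to compound 4, most probably reported again only as a limit.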

Compound 4, half-maximal inhibitory concentration: > 100000 nM
Compound 4 ended at the assay's limit (the forecaster's own chance of this, stated with the estimate: 80%); the middle value is on the limit's open side.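

No step can be read from compound 2 to compound 4, because both give only a limit, not a number: the limit of > 100000 nM in this assay, at which 3 of the 4 values shown sit. On these data alone, how far (4-methoxyphenyl)amino in place of 4-(tert-butyl)phenoxy changes activity in compound 4 stays open.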